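Aminophenyl to aminopyridinyl on the oxadiazole-linked nitroimidazole series

A few compounds are considered here, and "the series" means these few. Any claim that something is new, unique, unknown or untested is made for them only; others in the source may bear on it.

Compound 1 `Cc1ncc([N+](=O)[O-])n1CCSc1nnc(-c2ccccc2N)o1` gives 20100 nM in a functional assay on MCF7 cells (Homo sapiens) for cytotoxicity, read by MTT assay, with a stated time of 48 h (on this read-out higher numbers stand for weaker inhibition and lower numbers for stronger inhibition), the second highest of the three numbers; compound 3 `COc1cc(-c2nnc(SCCn3c([N+](=O)[O-])cnc3C)o2)cc(OC)c1OC` gives 30600 nM and compound 2 `COc1cc(OC)cc(-c2nnc(SCCn3c([N+](=O)[O-])cnc3C)o2)c1` gives 12800 nM, both within the scatter of compound 1. For the measured compounds named here, the only step between measured compounds, a 2.4-fold higher number from compound 2 to compound 3 (0.38 log units; beyond the scatter), concerns a methoxy group on the trimethoxyphenyl side and does not touch the aminophenyl part changed here. Compound 4 `Cc1ncc([N+](=O)[O-])n1CCSc1nnc(-c2cnccc2N)o1` differs from compound 1 by 4-aminopyridin-3-yl in place of 2-aminophenyl on an aromatic carbon: 2-aminophenyl leaves and 4-aminopyridin-3-yl enters. Going by the values given here, no measured step bears on this exchange, so no step beyond the scatter is expected in this assay. Compound 4 is therefore estimated at 20000 nM, range 7000 nM to 60000 nM, a step of a 1.0-fold lower number from compound 1 to compound 4 (0.00 log units; within the scatter) that is expected to stay within the scatter.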

Compound 4, half-maximal inhibitory concentration: 29300 nM
The estimate for compound 4 lay 1.5-fold (0.17 log units) below the measured number; low and high end bracket the measured number.
By their numbers in this assay, from the lowest: compounds 2, 1, 4 and 3 (each within the scatter of the next, the first and the last beyond it).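

In this assay, 4-aminopyridin-3-yl in place of 2-aminophenyl gives a 1.5-fold higher number from compound 1 to compound 4 (0.16 log units; within the scatter), so at this place on the shared core a ring nitrogen can enter the six-membered aromatic ring without a step beyond the scatter. This rests on a single pair, and the earlier step touched only methoxy groups. No measurement available here bears on the reason for this result.

On these data alone, whether the same holds for other groups at this place remains open, for example a carboxylic acid in place of the amine or a thiophene ring in place of the six-membered ring.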